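The source may report more compounds than this note shows. Statements on the series, on what has been measured and on what is new or still open speak of the compounds shown alone.

Measured in a functional assay on cells (Platelet, Homo sapiens) for inhibition; on this read-out higher numbers stand for weaker inhibition and lower numbers for stronger inhibition:
- compound 1 `CCOC(=O)c1ccc(-c2nn(Cc3ccc(Cl)cc3)c3ccccc23)cc1`: > 10000 nM
- compound 2 `CCOC(=O)c1cccc(-c2nn(Cc3ccccc3)c3ccccc23)c1`: > 10000 nM

Neither entry is a number. Compound 1 has only a limit in this assay, > 10000 nM, so its position is bounded on one side and no more. Compound 2 also has only a limit, > 10000 nM. Going by the values given here, the series so far therefore sits entirely at the limit of > 10000 nM in this assay, at which 2 of the 2 values shown sit.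

The next compound is compound 3 `CCOC(=O)c1ccc(-c2nn(Cc3ccccn3)c3ccccc23)cc1`. It carries pyridin-2-yl in place of 4-chlorophenyl on a saturated chain carbon bound to an aromatic nitrogen. The rest of the core of compound 1 is unchanged.

Among the compounds with values here, no step between measured compounds is available, so the size of this change cannot be read from the data. The working expectation is no shift beyond the scatter, and another limit is the likeliest outcome. This rests only on compound 1, whose reading is the limit > 10000 nM. The expected change is a step that the limit leaves unreadable from compound 1 to compound 3. In this assay the estimate for compound 3 is 15000 nM, expected to fall within 5000 nM to 40000 nM.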

Compound 3, half-maximal inhibitory concentration: > 10000 nM
Compound 3: only a limit was reported; the forecaster's own chance of this, stated with the estimate: 85%; the middle value lies beyond the limit too.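

No new step can be read: compound 1 and compound 3 both carry only limits in this assay, so the swap of 4-chlorophenyl for pyridin-2-yl has no readable size. The compounds shown leave open what structure on the shared core would give a measurable inhibition, since every reading so far is the same limit: the limit of > 10000 nM in this assay, at which 3 of the 3 values shown sit.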